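The source may report more compounds than this note shows. Statements on the series, on what has been measured and on what is new or still open speak of the compounds shown alone.

Measured so far:
compound 1 `COc1cc2ncnc(-n3nc(-c4ccccn4)nc3N)c2cc1OCc1ccccc1`: > 27000 nM
compound 2 `COc1cc2c(-n3nc(-c4ccccn4)nc3N)ncnc2cc1O`: > 27000 nM

In an ADME assay on BJ cells (Homo sapiens) for cytotoxicity, with a stated time of 72 h (a higher number here means that more compound is needed for the effect, a lower number that less compound is needed), compound 1 gives > 27000 nM, which is a limit of the assay and not a number. In this assay compound 2 likewise gives only a limit, > 27000 nM. Both values sit at the limit of > 27000 nM in this assay, at which 2 of the 2 values shown sit, so compound 1 cannot be placed relative to anything else on these numbers. Compound 3 `COc1cc2ncnc(-n3nc(-c4ccccn4)nc3N)c2cc1OCCCNC(=O)OC(C)C` is the next candidate. Against compound 1 the change is 2-((isopropoxycarbonyl)amino)ethyl in place of phenyl on a saturated chain carbon bound to an oxygen on an aromatic ring. Within the data shown here, no measured step between compounds differing in one place exists in this set. With both measured values at the limit, no step beyond the scatter is expected: a step that the limit leaves unreadable from compound 1 to compound 3. Compound 3 is estimated at 30000 nM in this assay, range 10000 nM to 100000 nM, most likely again reported as a limit.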

Compound 3, half-maximal effective concentration: > 13000 nM
Compound 3 was reported as a limit; the forecaster's own chance of this, stated with the estimate: 85%; the middle value lies beyond the limit too.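

Among these compounds, no step from compound 1 to compound 3 can be read in this assay, as both values are limits of the assay. The compounds shown leave open the concentration at which any of them would reach the half-maximal effect.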